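Benzamide series: removing one methoxy from compound 2

The source may report more compounds than this note shows. Statements on the series, on what has been measured and on what is new or still open speak of the compounds shown alone.

Compound 2 `COc1cc(C(=O)Nc2ccc(C(=O)/C=C/c3nc(C)c(C)nc3C)cc2)cc(OC)c1OC` in a functional assay on HepG2 cells (Homo sapiens) for antiproliferative activity, read by CCK-8 assay, with a stated time of 72 h (a lower number here means a stronger inhibitor, a higher number a weaker inhibitor), gives 4860 nM, the second highest of three numbers. Compound 1 `Cc1ccc(C(=O)Nc2ccc(C(=O)/C=C/c3nc(C)c(C)nc3C)cc2)cc1` gives 5450 nM, within the scatter of compound 2. Compound 3 `Cc1nc(C)c(/C=C/C(=O)c2ccc(NC(=O)c3ccc(F)cc3)cc2)nc1C` gives 2250 nM, a lower number than compound 2, beyond the scatter. Among the compounds with values here, the only single-point step, a 2.4-fold lower number from compound 1 to compound 3 (0.38 log units; beyond the scatter), concerns a different group and bears only loosely here. Compound 4 `COc1cc(OC)cc(C(=O)Nc2ccc(C(=O)/C=C/c3nc(C)c(C)nc3C)cc2)c1` differs from compound 2 by hydrogen in place of methoxy on an aromatic carbon, placed ortho to two methoxy groups and para to a large group. Compound 1 and compound 2 sit within the scatter of each other despite different substitution, so no step beyond the scatter is expected for compound 4: a 1.0-fold higher number from compound 2 to compound 4 (0.01 log units; within the scatter). Compound 4 is therefore estimated at 5000 nM, range 2400 nM to 10500 nM.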

Compound 4, half-maximal inhibitory concentration: 11000 nM
Compound 4: middle estimate off by 2.2-fold (0.34 log units), on the low side, outside the stated range (above it).
By their numbers in this assay, from the lowest: compound 3; then compounds 2, 1 and 4 (each within the scatter of the next, the first and the last beyond it).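

In this assay, hydrogen and methoxy are not interchangeable at this position, ortho to two methoxy groups and para to a large group: a 2.3-fold higher number from compound 2 to compound 4 (0.35 log units; beyond the scatter) is modest but beyond the scatter. The 3,5-dimethoxyphenyl group gives a 4.9-fold higher number from compound 3 to compound 4 (0.69 log units; beyond the scatter) against 4-fluorophenyl, but a 2.0-fold higher number from compound 1 to compound 4 (0.30 log units; within the scatter) against 4-methylphenyl stays within the scatter. Nothing available explains the effect of losing this methoxy. On these data alone, whether a hydroxyl, an amine or a longer alkoxy chain here would match methoxy remains open. So does whether this methoxy acts independently of the other two.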